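Amide variants on the shared core: step to a pyridyl amide

The source may report more compounds than this note shows. Statements on the series, on what has been measured and on what is new or still open speak of the compounds shown alone.

Measured so far:
compound 1 `COc1ccc(C(=O)Nc2ccccc2C)cc1OC1CCCC1` — 300 nM
compound 2 `COc1ccc(C(=O)Nc2c(F)cccc2Cl)cc1OC1CCCC1` — 240 nM
compound 3 `COc1ccc(C(=O)Nc2c(C)cccc2Cl)cc1OC1CCCC1` — 100 nM

All three numbers come from an assay on isolated protein for inhibition of phosphodiesterase 4A (Sus scrofa); on this read-out higher numbers stand for weaker inhibition and lower numbers for stronger inhibition. Compound 3 stands lowest of the three; the nearest is compound 2, a step of a 2.4-fold lower number from compound 2 to compound 3 (0.38 log units; beyond the scatter), the furthest compound 1, with a 3.0-fold lower number from compound 1 to compound 3 (0.48 log units; beyond the scatter). The step of a 1.3-fold lower number from compound 1 to compound 2 (0.10 log units; within the scatter) lies within the scatter.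

Compound 4 `COc1ccc(C(=O)Nc2ccccn2)cc1OC1CCCC1` is the next member. The change from compound 3 is pyridin-2-yl in place of 2-chloro-6-methylphenyl on an amide-type nitrogen. Within the data shown here, no measured pair repeats this: the ring that enters carries neither the chloro nor the methyl group of the ring that leaves, and it holds a nitrogen in the ring. The closest guide is that taking the chloro away gave a 3.0-fold lower number from compound 1 to compound 3 (0.48 log units; beyond the scatter) in reverse, and swapping methyl for fluoro gave a 2.4-fold lower number from compound 2 to compound 3 (0.38 log units; beyond the scatter) in reverse, both modest rises in number. Among the measured compounds shown here, compound 4 drops both groups at once, so a larger rise in this assay is expected, while the ring nitrogen has no precedent here and widens the range.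

Compound 4 is estimated at 800 nM in this assay, between 250 nM and 2500 nM. This estimate means an expected step of an 8.0-fold higher number from compound 3 to compound 4 (0.90 log units; beyond the scatter).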

Compound 4, half-maximal inhibitory concentration: 1000 nM
Estimate against measurement, compound 4: 1.3-fold (0.10 log units) below, and the stated range covers the measured number.
By their numbers in this assay, from the lowest: compound 3; then compounds 2 and 1 (each within the scatter of the next); then compound 4.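

In this assay, pyridin-2-yl on the amide-type nitrogen gives a higher number than each of the three substituted phenyl groups: a 10-fold higher number from compound 3 to compound 4 (1.00 log units; beyond the scatter) and a 4.2-fold higher number from compound 2 to compound 4 (0.62 log units; beyond the scatter) and also a 3.3-fold higher number from compound 1 to compound 4 (0.52 log units; beyond the scatter) on the same change of ring. Among these compounds, the earlier compounds showed only how far the number moves among substituted phenyl groups, whereas this result shows that the number at this place also moves when the ring carries a ring nitrogen and neither chloro, fluoro nor methyl; the rise holds against all three, even compound 1 with its single methyl group. Nothing available bears on why the number rises with this change.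

The compounds shown leave open how much of the rise belongs to the ring nitrogen and how much to the loss of the ring substituents, as the two changes arrive together in compound 4. A plain phenyl group on the amide-type nitrogen would bear on the first question, and a pyridin-2-yl ring carrying chloro and methyl groups or an amine would bear on the second.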